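The source may hold more compounds than are shown below. What is called first, only, known or untested is meant among the compounds shown, and "the series" means these compounds.

Of the compounds shown here, two sharing one core have been measured so far. Compound 1 `CN1Cc2ccc(OCCC3CCCCC3)cc2[C@@H](O)C1` carries a 2-cyclohexylethoxy group on the aromatic ring. In an ADME assay on Vero cells (Chlorocebus sabaeus) for cytotoxicity, read by sulforhodamine B assay, with a stated time of 72 h (a lower number here means a stronger inhibitor, a higher number a weaker inhibitor), compound 1 reaches only the limit of the assay, > 50000 nM. Compound 2 `CN1Cc2ccc(O)cc2[C@@H](OCCC2CCCCC2)C1` places the same chain elsewhere on the core. In this assay compound 2 likewise gives only a limit, > 50000 nM. Compound 2 therefore stands at the limit of > 50000 nM in this assay, at which 2 of the 2 values shown sit, with no number of its own. Compound 3 `CN1Cc2ccc(OCCC3CCCCC3)cc2[C@@H](OCCC2CCCCC2)C1` differs from compound 2 by 2-cyclohexylethyl in place of hydrogen on an oxygen on an aromatic ring. For the measured compounds named here, no measured step of this kind exists, so the expected step of a number no higher from compound 2 to compound 3 (the limit leaves the size open) is none beyond the scatter. Compound 3 is expected to give 50000 nM, within 15000 nM to 150000 nM.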

Compound 3, half-maximal inhibitory concentration: 23600 nM
Beside the measured number, compound 3's estimate is 2.1-fold (0.33 log units) above it; the range from low to high includes it.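

In this assay, 2-cyclohexylethyl on an oxygen on an aromatic ring gives an at least 2.1-fold lower number from compound 2 to compound 3 (0.32 log units; beyond the scatter), and 2-cyclohexylethyl on an oxygen on a saturated carbon gives an at least 2.1-fold lower number from compound 1 to compound 3 (0.32 log units; beyond the scatter). Compound 3, which carries the chain in both places, is thus the only one of the three with a measured number rather than a limit. Neither step has a known size, because each starts from a limit: the limit of > 50000 nM in this assay, at which 2 of the 3 values shown sit.

The compounds shown leave open whether a shorter chain or an amine in place of either 2-cyclohexylethyl group would also give a measured number in this assay.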